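Urea series: swapping the chloro-trifluoromethylphenyl substitution pattern

This account rests on a few compounds, and the source may have more. Where it says the series, first, only, none or still open, it means among the compounds named here.

Measured compounds in a functional assay on MX1 cells (Homo sapiens) for inhibition, read by MTT assay, with a stated time of 120 h; a higher number here means a weaker inhibitor, a lower number a stronger inhibitor:
compound 1 `CNC(=O)C#Cc1ccc(NC(=O)Nc2ccc(Cl)c(C(F)(F)F)c2)cc1`, 26400 nM
compound 2 `CNC(=O)/C=C(\C)c1ccc(NC(=O)Nc2ccc(Cl)c(C(F)(F)F)c2)cc1`, a limit, > 50000 nM
compound 3 `CC(NC(=O)c1ccc(-c2ccc(NC(=O)Nc3cc(C(F)(F)F)ccc3Cl)cc2)cc1)c1ccccc1`, 17700 nM

The value for compound 2 is a limit of this assay, (the limit of > 50000 nM in this assay, at which 1 of the 3 values shown sits). Compound 3 has the lowest of the two numbers shown; compound 1 is nearest to it, within the scatter. Among the compounds with values here, the only measured step, an at least 1.8-fold higher number from compound 1 to compound 2 (0.27 log units; that floor lies within the scatter), concerns the other end of the molecule and does not bear on the change to compound 4 `CC(NC(=O)c1ccc(-c2ccc(NC(=O)Nc3ccc(Cl)c(C(F)(F)F)c3)cc2)cc1)c1ccccc1`. That change is 4-chloro-3-(trifluoromethyl)phenyl in place of 2-chloro-5-(trifluoromethyl)phenyl on an amide-type nitrogen. Within the data shown here, no measured pair isolates this swap, so no step beyond the scatter is expected. For compound 4 the estimate is 12000 nM, range 3000 nM to 45000 nM. The expected step is a 1.5-fold lower number from compound 3 to compound 4 (0.17 log units; within the scatter).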

Compound 4, half-maximal inhibitory concentration: 4630 nM
Estimate against measurement, compound 4: 2.6-fold (0.41 log units) above; low and high end bracket the measured number.
By their numbers in this assay, from the lowest: compound 4; then compounds 3 and 1 (each within the scatter of the next). At a limit, above all of these: compound 2.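

In this assay, the step of a 3.8-fold lower number from compound 3 to compound 4 (0.58 log units; beyond the scatter) comes with 4-chloro-3-(trifluoromethyl)phenyl in place of 2-chloro-5-(trifluoromethyl)phenyl on an amide-type nitrogen, with the same atoms and the rest of the molecule unchanged. Unlike the earlier step, whose floor lay within the scatter, this one shows that the arrangement of these two substituents alone changes the number at this position. No measured property shown here accounts for the difference.

Still open, going by these compounds, is whether chlorine or trifluoromethyl alone carries this step. A 3,4-dichlorophenyl group at this place would test that, and a carboxylic acid at the far end of the molecule would test whether the step holds there.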